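The compounds below may be only part of what the source reports. "The series", "measured", "known", "first", "only" and "open" are said of these compounds alone.

Measured compounds:
Compound 1 `O=C(Nc1cc(C(F)(F)F)cc(C(F)(F)F)c1)C1CCc2ccccc2N1C(=O)c1ccc(Cl)cc1`: 4230 nM
Compound 2 `O=C(Nc1ccccc1O)C1CCc2ccccc2N1C(=O)c1ccccc1`: 5690 nM

Of the compounds shown here, two have been measured in a functional assay on PC-3 cells (Homo sapiens) for cytotoxicity, read by sulforhodamine B assay, with a stated time of 72 h; on this read-out lower numbers stand for stronger inhibition of growth and higher numbers for weaker inhibition of growth. Compound 1 gives 4230 nM, and compound 2 gives 5690 nM; the two numbers stand within the usual scatter of each other, so compound 1 stands on a par with compound 2 rather than apart from it. Compound 3 `O=C(Nc1cc(C(F)(F)F)cc(C(F)(F)F)c1)C1CCc2ccccc2N1C(=O)c1ccccc1` has not yet been measured. It differs from compound 1 by hydrogen in place of chloro on an aromatic carbon, the same difference, cut one bond further out, reading 4-chlorophenyl to phenyl. Among the measured compounds shown here, no measured pair in this set shows that change on its own, so its effect can only be expected, not read off. Compound 3 is expected to show a step of a 1.4-fold higher number from compound 1 to compound 3 (0.15 log units; within the scatter) in this assay, which would be small and at most a modest move toward weaker inhibition of growth, no clearer than the scatter. Compound 3 is therefore estimated at 6000 nM, within a range from 2500 nM to 15000 nM.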

Compound 3, concentration for 50% growth inhibition: 3500 nM
Beside the measured number, compound 3's estimate is 1.7-fold (0.23 log units) above it; the range from low to high includes it.
By their numbers in this assay, from the lowest: compounds 3, 1 and 2 (each within the scatter of the next).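

In this assay, among the compounds shown here, this is the first pair to isolate one change: hydrogen in place of chloro on an aromatic carbon, para to a large group, gives a 1.2-fold lower number from compound 1 to compound 3 (0.08 log units; within the scatter). Removing the chloro therefore leaves the reading of the series undisturbed, and on this background the position tolerates either hydrogen or chloro without a step that stands clear of the scatter. Nothing shown here offers an explanation for this result.

The compounds shown carry only hydrogen or chloro at this position, so it stays open whether an amine, a carboxylic acid or a methoxy group there would give a step beyond the scatter. From the compounds shown here alone, it also stays open whether chloro in place of hydrogen on the benzoyl of compound 2 would give a step of similar size.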